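Cyclohexyl for isopropyl on the sulfur

The source may hold more compounds than are shown below. What is called first, only, known or untested is meant among the compounds shown, and "the series" means these compounds.

For the measured compounds named here, in a functional assay on MT4 cells (Homo sapiens) for cytotoxicity (on this read-out higher numbers stand for lower toxicity in this test and lower numbers for higher toxicity in this test), compound 1 (`CC(C)Sc1nc(O)cc(C(C)c2cccc3ccccc23)n1`) gives 119000 nM, the higher of the two numbers so far, while compound 2 (`CCC(c1cc(O)nc(SC(C)C)n1)c1cccc2ccccc12`) gives 16900 nM. Compound 3 (`CC(c1cc(O)nc(SC2CCCCC2)n1)c1cccc2ccccc12`) differs from compound 1 by cyclohexyl in place of isopropyl on a sulfur. Going by the values given here, no measured step changes that group. Among the compounds with values here, the only guide is the modest step of a 7.0-fold lower number from compound 1 to compound 2 (0.85 log units; beyond the scatter), which also adds carbon, though elsewhere. A lower number of similar or smaller size is therefore expected, an estimated step of a 3.0-fold lower number from compound 1 to compound 3 (0.47 log units; beyond the scatter). For compound 3 the expected value is 40000 nM, with an estimated range of 12000 nM to 120000 nM.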

Compound 3, half-maximal cytotoxic concentration: 45000 nM
Beside the measured number, compound 3's estimate is 1.1-fold (0.05 log units) below it, within the range that was stated.
By their numbers in this assay, from the lowest: compound 2; then compound 3; then compound 1.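

In this assay, the sulfur substituent proves to be a position that affects the read-out: cyclohexyl in place of isopropyl gives a 2.6-fold lower number from compound 1 to compound 3 (0.42 log units; beyond the scatter). For the compounds shown here, the saturated chain carbon is therefore no longer the only place where a change is seen to lower the number, as it did in a 7.0-fold lower number from compound 1 to compound 2 (0.85 log units; beyond the scatter). Nothing available accounts for this shift at the sulfur. Going by these compounds, whether a phenyl group or a straight butyl chain on the sulfur would lower the number as well remains open. So does the outcome of pairing cyclohexyl with the added methyl of compound 2.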